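The source may report more compounds than this note shows. Statements on the series, on what has been measured and on what is new or still open speak of the compounds shown alone.

Of the compounds shown here, two with a shared core have been measured so far. In a functional assay on the whole organism for inhibition, with Mus musculus as the target (on this read-out lower numbers stand for an effect already at smaller amounts and higher numbers for an effect only at larger amounts of compound), compound 1 (`Cc1ccc(C2CN(C)Cc3c(N)cccc32)cc1`) gives 1.6 mg/kg, while compound 2 (`CCCCNC(=O)Nc1cccc2c1CN(C)CC2c1ccccc1`) gives about 40 mg/kg. Compound 2 therefore has the higher of the two numbers, and the gap between them lies well beyond the usual scatter. It needs a much larger dose for the same effect.

Compound 3 (`CCCCNC(=O)Nc1cccc2c1CN(C)CC2c1ccc(C)cc1`) is compound 2 with one small edit, a phenyl turned into a 4-methylphenyl: methyl in place of hydrogen on an aromatic carbon. In words, this is methyl in place of hydrogen on an aromatic carbon.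

For the measured compounds named here, no measured pair isolates this edit. Compound 1, at 1.6 mg/kg, also carries the 4-methylphenyl, but it differs from compound 2 in another place too, so its low number offers only a weak hint. In this assay, a small shift toward a lower number is therefore expected, quite possibly none beyond the scatter. The expected size is a 1.6-fold lower number from compound 2 to compound 3 (0.20 log units; within the scatter). For compound 3 the estimated value is 25 mg/kg, with an expected range from 8 mg/kg to 70 mg/kg.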

Compound 3, dose for half-maximal effect: 40 mg/kg
Compound 3: middle estimate off by 1.6-fold (0.20 log units), on the low side; the measured number falls inside the stated range.
By their numbers in this assay, from the lowest: compound 1; then compounds 2 and 3 (each within the scatter of the next).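

In this assay the methyl on the aromatic carbon can now be read on its own, and the pair shows no change at the digits printed from compound 2 to compound 3 (within the scatter) with the butylcarbamoyl group in place, so this edit, para to a large group, has no effect that stands out from the scatter. The second pair, which shares the 4-methylphenyl and differs only on the nitrogen, shows a 25-fold higher number from compound 1 to compound 3 (1.40 log units; beyond the scatter) and ties the large gap to butylcarbamoyl in place of hydrogen, so the low number of compound 1 cannot be credited to the 4-methylphenyl alone, as compound 3 carries that group too. No measurement shown here gives a reason for either result.

Still open, as far as these compounds go, is whether a chlorine or a methoxy group on that same aromatic carbon would behave like methyl, and whether methyl would matter in a compound that keeps the free amine and has a plain phenyl. Also open, from the compounds shown here alone, is how much of the butylcarbamoyl group goes with the large step, which an acetyl group or a shorter chain on that nitrogen could help to separate.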